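Removing the Nitro Group from a Thromboxane Receptor Antagonist

The source may hold more compounds than are shown below. What is called first, only, known or untested is meant among the compounds shown, and "the series" means these compounds.

Three measured compounds share one core and differ at the edges. Compound 1 `Cc1ccc(S(=O)(=O)N[C@H]2CCC=C2CCCCOCC(=O)O)cc1` carries a 4-methylphenyl on the sulfonyl sulfur; in a functional assay on a cell-free system (plasma) for inhibition of thromboxane A2 receptor (Homo sapiens), read by turbidimetry (on this read-out lower numbers stand for stronger inhibition and higher numbers for weaker inhibition), compound 1 gives 1900 nM. Compound 2 `O=C(O)COCCCCC1=CCC[C@@H]1NS(=O)(=O)c1ccccc1[N+](=O)[O-]` bears a 2-nitrophenyl there instead, and in this assay compound 2 gives 1900 nM. Compound 3 `O=C(O)CCC/C=C\CC1=CCC[C@@H]1NS(=O)(=O)c1ccccc1[N+](=O)[O-]` keeps the 2-nitrophenyl but has a 5-carboxypent-1-en-1-yl chain in place of the 3-(carboxymethoxy)propyl chain; in this assay compound 3 gives 680 nM. Compound 2 thus stands level with compound 1 at the digits shown, the two together the highest numbers of the three, while compound 3 sits lower: a 2.8-fold lower number from compound 2 to compound 3 (0.45 log units; beyond the scatter).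

Compound 4 `O=C(O)COCCCCC1=CCC[C@@H]1NS(=O)(=O)c1ccccc1` differs from compound 2 in one place: hydrogen in place of nitro on an aromatic carbon. The step that bears most on this change is the one at the same ring, no change at the digits printed from compound 1 to compound 2 (within the scatter), where exchanging one aryl group for another left the number unchanged within the scatter. Among the measured compounds shown here, the only step beyond the scatter, the chain change, does not touch the ring. For the measured compounds named here, no measured step isolates the nitro itself, so the expectation rests on that aryl swap. Compound 4 is therefore expected to give about 1900 nM, in the range 800 nM to 4500 nM. This estimate means a step of no change at the digits printed from compound 2 to compound 4 (within the scatter), expected to lie within the scatter.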

Compound 4, half-maximal inhibitory concentration: 2000 nM
Beside the measured number, compound 4's estimate is 1.1-fold (0.02 log units) below it; low and high end bracket the measured number.
By their numbers in this assay, from the lowest: compound 3; then compounds 1, 2 and 4 (each within the scatter of the next).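

In this assay, taking the nitro off the aromatic ring gives a 1.1-fold higher number from compound 2 to compound 4 (0.02 log units; within the scatter) and so shows directly that at this position the nitro group can be replaced by hydrogen without the number leaving the scatter. The same plain phenyl ring also gives a 1.1-fold higher number from compound 1 to compound 4 (0.02 log units; within the scatter) and thereby adds a reference point that the earlier aryl swap lacked: on the 3-(carboxymethoxy)propyl chain, the rings bearing nitro, methyl or neither all stand level. Nothing measured here explains why these three rings stand level.

Among the compounds shown here, the only compound with the 5-carboxypent-1-en-1-yl chain, compound 3, carries the 2-nitrophenyl, so it remains open whether that chain would also give a lower number with a plain phenyl ring. Also open, going by these compounds, is whether another group on the aromatic ring, such as an amine or a chlorine, would stay level with these three or move the number beyond the scatter.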